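A few compounds are considered here, and "the series" means these few. Any claim that something is new, unique, unknown or untested is made for them only; others in the source may bear on it.

Measured so far in a functional assay on DU-145 cells (Homo sapiens) for inhibition, read by trypan blue exclusion, with a stated time of 96 h; on this read-out higher numbers stand for weaker inhibition of growth and lower numbers for stronger inhibition of growth:

compound 1 `O=C(O)c1ccc(C(=O)/C(=C\c2ccc(Br)c([N+](=O)[O-])c2)SCc2ccc(F)cc2)cc1` gives 1000 nM
compound 2 `COc1ccc(/C=C(/SCc2ccc(F)cc2)C(=O)c2ccc(Br)cc2)cc1O` gives 1000 nM

In this assay compound 2 stands level with compound 1, the two values lying within the usual scatter of each other. Compound 3 `COc1ccc(/C=C(/SCc2ccc(F)cc2)C(=O)c2ccc(C(=O)O)cc2)cc1O` has not yet been measured. It differs from compound 2 in one place: carboxy in place of bromo on an aromatic carbon, which is carboxy in place of bromo on an aromatic carbon, para to a large group, or 4-bromophenyl to 4-carboxyphenyl.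

Within the data shown here, no two measured compounds differ in one place only, so the data give no direct measure of this change. Among the measured compounds shown here, the only guide is compound 1, which carries the same 4-carboxyphenyl group and gives 1000 nM, although it also differs from compound 2 elsewhere. On that slender basis, the expected change in this assay is none beyond the scatter, in either direction, with an estimated no change at the digits printed from compound 2 to compound 3 (within the scatter). For compound 3 the estimated value is 1000 nM, with an expected range from 300 nM to 3500 nM.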

Compound 3, concentration for 50% growth inhibition: 10000 nM
For compound 3 the middle estimate is 10-fold (1.00 log units) below the measured one; measured number above the stated range.
By their numbers in this assay, from the lowest: compounds 1 and 2 (each within the scatter of the next); then compound 3.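

In this assay, among these compounds, carboxy in place of bromo on an aromatic carbon, para to a large group, gives a 10-fold higher number from compound 2 to compound 3 (1.00 log units; beyond the scatter) and so provides the first direct reading of this change. The number moves beyond the scatter, which shows that this position does not accept every group equally when the 3-hydroxy-4-methoxyphenyl group is present. The 4-carboxyphenyl group does not fix the number on its own, since 3-hydroxy-4-methoxyphenyl in place of 4-bromo-3-nitrophenyl gives a 10-fold higher number from compound 1 to compound 3 (1.00 log units; beyond the scatter) and leaves compound 3 apart from both of its one-place neighbours.

The compounds shown leave open whether a primary amide, a nitrile or a methyl ester in place of bromo would stay level with compound 2 or move towards compound 3. They also leave open whether chloro or an amine at the same position would give a number close to that of compound 2. Nothing available here accounts for the size of either step.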